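Benzyl to pentyl on the imide nitrogen: cytotoxicity notes

The compounds below may be only part of what the source reports. "The series", "measured", "known", "first", "only" and "open" are said of these compounds alone.

Three compounds have been run in an ADME assay on SW480 cells (Homo sapiens) for cytotoxicity, read by MTT assay, with a stated time of 72 h; a lower number here means a stronger inhibitor, a higher number a weaker inhibitor. Compound 1 `Cc1ccc(NC(=O)c2cccc(/C=C3\CC(=O)N(c4ccccc4)C3=O)c2)cc1` returns only a limit, > 100000 nM. Compound 3 `COc1ccc(NC(=O)c2cccc(/C=C3\CC(=O)N(c4ccccc4)C3=O)c2)cc1` likewise returns only a limit, > 100000 nM. Among the compounds with values here, compound 2 `CCc1cccc(NC(=O)c2cccc(/C=C3\CC(=O)N(Cc4ccccc4)C3=O)c2)c1` gives the single actual number in this assay, 91500 nM. Within the data shown here, the one single-point step measured, a step that the two limits leave unreadable from compound 1 to compound 3, stays unreadable, and the limit of > 100000 nM in this assay, at which 2 of the 3 values shown sit, marks where two of the three results sit. Compound 4 `CCCCCN1C(=O)C/C(=C\c2cccc(C(=O)Nc3cccc(CC)c3)c2)C1=O` differs from compound 2 by butyl in place of phenyl on a saturated chain carbon bound to an amide-type nitrogen in a ring. No measured step touches this position; the numbers shown support neither a size nor a direction for the change, and the result for compound 2 itself lies near the top of the measured range. Only a shift within the usual spread is expected, a 1.2-fold higher number from compound 2 to compound 4 (0.08 log units; within the scatter). Compound 4 is estimated at 110000 nM, between 40000 nM and 300000 nM, with a fair chance that this assay again returns only a limit.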

Compound 4, half-maximal inhibitory concentration: 83300 nM
Compound 4: middle estimate off by 1.3-fold (0.12 log units), on the high side, and the stated range covers the measured number.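

Within the data shown here, on a saturated chain carbon bound to an amide-type nitrogen in a ring, this assay now gives a first readable step for butyl in place of phenyl: a 1.1-fold lower number from compound 2 to compound 4 (0.04 log units; within the scatter). Read one bond further out, benzyl to pentyl removes the aromatic ring at this place, yet the two compounds stay within the scatter of each other. Compound 4 also returns an actual number, not a limit.

Still open, on these data alone, is whether an amine, a carboxylic acid or a longer chain at this place would give a step beyond the scatter.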